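Replacing the cyano-bearing amidine of compound 2 with a sulfur-bearing group

The source may hold more compounds than are shown below. What is called first, only, known or untested is meant among the compounds shown, and "the series" means these compounds.

Compound 2 `CN(C)/C(=N/CCCCn1nc(-c2ccccc2)ccc1=O)NC#N` gives 80.7% in a functional assay on the whole organism with Rattus norvegicus as the target, at a dose of 100 mg/kg (a lower number here means less inhibition, a higher number more inhibition at the dose given (going by the name of the read-out)), the highest of the three numbers obtained so far; compound 1 `C/N=C(\S)NCCCCn1nc(C)ccc1=O` gives 44.5% and compound 3 `C#CCN/C(=N/CCCCn1nc(-c2ccccc2)ccc1=O)NC#N` gives -12.9%. Among the compounds with values here, the only single-point step among them is a number 93.6 percentage points lower from compound 2 to compound 3 (beyond the scatter), which shows how strongly the read-out can fall when the substituent on the carbon with a double bond to nitrogen is altered.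

Compound 4 `CC/N=C(\S)NCCCCn1nc(-c2ccccc2)ccc1=O` differs from compound 2 as follows: a group of 6 heavy atoms (3 carbon, 2 nitrogen, 1 sulfur; no ring) in place of a group of 8 heavy atoms (4 carbon, 4 nitrogen; no ring), on a saturated chain carbon, four bonds along the chain from an aromatic nitrogen. Within the data shown here, no measured step matches this exchange. Compound 1 carries a sulfur-bearing group of the same kind, but it also differs in the substituent on the shared core, so its value of 44.5% only shows that such a group is compatible with a moderate read-out. A fall beyond the scatter is therefore expected, though smaller than the step to compound 3. Compound 4 is expected to give 50% (range 10% to 85%), an estimated step of a number 30.7 percentage points lower from compound 2 to compound 4 (beyond the scatter).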

Compound 4, a percentage reported as inhibition, in the whole organism at one dose (the size of the read-out at that dose, not a potency): 67.7%
The estimate for compound 4 lay 17.7 percentage points below the measured number, within the range that was stated.
By their numbers in this assay, from the lowest: compound 3; then compound 1; then compound 4; then compound 2.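

The exchange on a saturated chain carbon, four bonds along the chain from an aromatic nitrogen, comes to a number 13 percentage points lower from compound 2 to compound 4 (beyond the scatter) in this assay, a modest step for the replacement of the whole group, whereas the change of one substituent within that group came to a number 93.6 percentage points lower from compound 2 to compound 3 (beyond the scatter) in the same read-out. The nitrile is therefore not needed for a high read-out on this core, which compound 1 could not show, as it also differs in the substituent on the shared core. Nothing available here explains why the sulfur-bearing group holds up so well.

The compounds shown leave open whether the read-out would hold with an oxygen in place of the sulfur, or with a propyl chain in place of the ethyl. They also leave open how much of the gap between compound 1 and compound 4 belongs to the substituent on the shared core.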